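The compounds below may be only part of what the source reports. "The series", "measured", "known", "first", "only" and "open" are said of these compounds alone.

Compound 1 `O=C(NCCCO)Nc1ccccc1CN1CCC(Cc2ccccc2)CC1` carries a urea whose far end is a 3-hydroxypropyl chain. In an in vitro assay on CHO cells for inhibition of C-C chemokine receptor type 1 (Homo sapiens) (a lower number here means a stronger inhibitor, a higher number a weaker inhibitor), compound 1 gives > 10000 nM, which is a limit of the measurement rather than a number. Compound 1 thus stands at the limit of > 10000 nM in this assay, at which 1 of the 2 values shown sits. Compound 2 `c1ccc(CCCCN2CCC(Cc3ccccc3)CC2)cc1` lacks the urea altogether. In this assay compound 2 gives > 50000 nM, again only a limit. Compound 2 sits at the limit of > 50000 nM in this assay, at which 1 of the 2 values shown sits. Within the data shown here, both values shown are limits, so no measured step between compounds is available here, and nothing yet shows how far a change on the urea can move the result.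

Compound 3 `COc1ccc(NC(=O)Nc2ccccc2CN2CCC(Cc3ccccc3)CC2)cc1` has not been measured. It differs from compound 1 in one place: 4-methoxyphenyl in place of 3-hydroxypropyl on an amide-type nitrogen. Among the measured compounds shown here, a six-membered aromatic ring replaces a short open chain at the end of the urea, and with only limits in hand no measured step sets the size of such a change. The expected step from compound 1 to compound 3 in this assay is an at least 33-fold lower number from compound 1 to compound 3 (1.52 log units; beyond the scatter), in the direction of stronger inhibition. Compound 3 is therefore estimated at about 300 nM, with a range from 40 nM to 5000 nM.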

Compound 3, half-maximal inhibitory concentration: > 10000 nM
Compound 3 gave a limit, no number; the forecaster's own chance of this, stated with the estimate: 20%; at least 33-fold (1.52 log units) between middle value and limit.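

Among these compounds, compound 3 gives only a limit, as compound 1 does, so no step between compound 1 and compound 3 can be read: the limit of > 10000 nM in this assay, at which 2 of the 3 values shown sit. The compounds shown leave open how strongly any of them inhibits in this assay, and whether any group at the end of the urea can give a measurable value.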